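This account rests on a few compounds, and the source may have more. Where it says the series, first, only, none or still open, it means among the compounds named here.

Working notes on the series. Two amides on the shared core have been measured in a functional assay on cells for positive allosteric modulation of metabotropic glutamate receptor 5 (Rattus norvegicus), read by calcium flux; a lower number here means that less compound is needed, a higher number that more compound is needed for the effect. Compound 1 `Cc1ccc(C(=O)Nc2cc(-c3ccccc3)nn2-c2ccccc2)cc1C` gives 20 nM in this assay, and compound 2 `O=C(Nc1cc(-c2ccccc2)nn1-c1ccccc1)c1ccncc1` gives 2500 nM in this assay. Among the measured compounds shown here, the single measured step, a 130-fold higher number from compound 1 to compound 2 (2.10 log units; beyond the scatter), is the only change recorded at the carbonyl carbon. For the measured compounds named here, compound 2 therefore stands at the highest of the two numbers, with compound 1 as its sole neighbour.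

Compound 3 `O=C(Nc1cc(-c2ccccc2)nn1-c1ccccc1)C1CCCC1` differs from compound 2 by cyclopentyl in place of pyridin-4-yl on a carbonyl carbon. The step that bears on it is the one at the same carbonyl carbon, a 130-fold higher number from compound 1 to compound 2 (2.10 log units; beyond the scatter), which was large, so the substituent at this position clearly moves the number in this assay. The cyclopentyl group is not the 3,4-dimethylphenyl of compound 1, so only part of that shift is expected to return. For compound 3 a number around 250 nM is estimated, in the range 50 nM to 1200 nM, which means an expected step of a 10-fold lower number from compound 2 to compound 3 (1.00 log units; beyond the scatter).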

Compound 3, half-maximal effective concentration: 3410 nM
Estimate against measurement, compound 3: 14-fold (1.13 log units) below; measured number above the stated range.
By their numbers in this assay, from the lowest: compound 1; then compounds 2 and 3 (each within the scatter of the next).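

In this assay, the step from the aromatic pyridin-4-yl to the non-aromatic, carbon-only cyclopentyl ring on the carbonyl carbon is a 1.4-fold higher number from compound 2 to compound 3 (0.13 log units; within the scatter), so these two groups cannot be told apart here. The comparison with 3,4-dimethylphenyl gives a 170-fold higher number from compound 1 to compound 3 (2.23 log units; beyond the scatter), which shows that the large step is not specific to pyridin-4-yl: among the three amides, only compound 1 has the low number. Nothing on hand accounts for this result.

On these data alone, it remains open whether the low number of compound 1 depends on the benzene ring, on its two methyl groups, or on both. An unsubstituted phenyl and a single-methyl methylphenyl group on the same carbonyl carbon would separate these possibilities.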